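Series notes: agonist read-out and the amine substituent

The compounds below may be only part of what the source reports. "The series", "measured", "known", "first", "only" and "open" are said of these compounds alone.

Compound 1 `C[C@@H]1CN(c2cccc3c2C[C@H](CN(C)[C@H]2CCCc4cccnc42)NC3)C[C@H](C)N1`, compound 2 `Cc1cnc2c(c1)CCC[C@@H]2N(C)C[C@H]1Cc2c(cccc2N2CCNCC2)CN1` and compound 3 `c1cnc2c(c1)CCC[C@@H]2N(CC1CCCCC1)C[C@H]1Cc2c(cccc2N2CCNCC2)CN1` share one core and differ in what sits on the amine. In a functional assay on CCRF-CEM cells for agonist activity at C-X-C chemokine receptor type 4 (Homo sapiens), read by calcium flux, with a stated time of 25 min (on this read-out higher numbers stand for an effect only at larger amounts of compound and lower numbers for an effect already at smaller amounts), compound 1 reaches only the limit of the assay, > 30000 nM. In this assay compound 2 likewise returns only a limit, > 30000 nM. In this assay compound 3 also stands at a limit, > 30000 nM, so no number is known for it. All three values sit at the same place, (the limit of > 30000 nM in this assay, at which 3 of the 3 values shown sit); no step between any two of these compounds can be stated, and the three limits show the same thing and nothing more.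

Compound 4 `CN(C[C@H]1Cc2c(cccc2N2CCNCC2)CN1)[C@H]1CCCc2cccnc21` is not yet measured. It differs from compound 3 in one place: hydrogen in place of cyclohexyl on a saturated chain carbon bound to an amine nitrogen. Because three of three values sit at the limit of > 30000 nM in this assay, at which 3 of the 3 values shown sit, the expectation for compound 4 in this assay is a further limit rather than a number. The step from compound 3 to compound 4 is expected to be a number no higher from compound 3 to compound 4 (the limit leaves the size open), none beyond the scatter in either direction. Compound 4 is accordingly estimated at 30000 nM, with a range from 10000 nM to 100000 nM, the upper end most likely.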

Compound 4, half-maximal effective concentration: > 30000 nM
Compound 4: only a limit was reported (the forecaster's own chance of this, stated with the estimate: 85%); the middle value sits exactly at the limit.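

In this assay compound 4 gives only a limit (> 30000 nM) and no number. No new step can be read from compound 1, compound 2 or compound 3 to compound 4: the limit of > 30000 nM in this assay, at which 4 of the 4 values shown sit. The compounds shown leave open whether any change on the shared core gives a measurable value in this assay and how large any step among them would be.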